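This account rests on a few compounds, and the source may have more. Where it says the series, first, only, none or still open, it means among the compounds named here.

In a functional assay on MCF7 cells (Homo sapiens) for inhibition, read by sulforhodamine B assay, with a stated time of 48 h (on this read-out higher numbers stand for weaker inhibition of growth and lower numbers for stronger inhibition of growth), compound 1 `N#CCC1=NN=C(c2ccc([N+](=O)[O-])cc2)C(CC(=O)c2ccc([N+](=O)[O-])cc2)O1` gives 1600 nM and compound 2 `N#CCC1=C(C#N)CC(c2ccc(Br)cc2)=C(CC(=O)c2ccc(Br)cc2)O1` gives 12000 nM while compound 3 `N#CCC1=C(C#N)CC(c2ccc([N+](=O)[O-])cc2)=C(CC(=O)c2ccc([N+](=O)[O-])cc2)O1` gives 30 nM as the lowest of the three numbers, beyond the scatter from both others. Compound 4 `N#CCC1=C(C#N)CC(c2ccc([N+](=O)[O-])cc2)=C(CC(=O)c2ccc(Br)cc2)O1` differs from compound 3 by one change (bromo in place of nitro on an aromatic carbon), bromo in place of nitro on an aromatic carbon. Going by the values given here, no step for this single change has been measured. Compound 2 carries 4-bromophenyl in both places where compound 3 carries 4-nitrophenyl, and compound 2 stands at 12000 nM against compound 3 at 30 nM on this comparison. A step to a higher number beyond the scatter, covering part of that gap, is therefore expected in this assay for the single replacement. The step expected is a 17-fold higher number from compound 3 to compound 4 (1.22 log units; beyond the scatter) in this estimate. The value expected for compound 4 is 500 nM (estimated range 80 nM to 3000 nM).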

Compound 4, concentration for 50% growth inhibition: 4900 nM
Compound 4: the middle estimate sits 9.8-fold (0.99 log units) below what was measured; measured number outside the range, above it.
By their numbers in this assay, from the lowest: compound 3; then compound 1; then compound 4; then compound 2.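

In this assay, going by these compounds alone, the single change from 4-nitrophenyl to 4-bromophenyl gives a 160-fold higher number from compound 3 to compound 4 (2.21 log units; beyond the scatter) and so carries most of the gap between the doubly substituted compounds. The change at the other place, nitro in place of bromo, gives only a 2.4-fold lower number from compound 2 to compound 4 (0.39 log units; beyond the scatter) and recovers little, so among these compounds the two places do not count equally. Nothing available here explains the size of the step. The compounds shown leave open whether an amine or a carboxylic acid on this aromatic carbon would keep the low number of compound 3.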